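Swapping cyclopentyl for isopropyl in compound 1

The source may hold more compounds than are shown below. What is called first, only, known or untested is meant among the compounds shown, and "the series" means these compounds.

- Compound 1 `O=C1NC(=O)C(Cc2ccc(OCC3CCCC3)cc2)S1` gives 25000 nM
- Compound 2 `O=C1NC(=O)/C(=C/c2ccc(OCC3CCC3)cc2)S1` gives 13000 nM

Among the compounds with values here, in a functional assay on PC-12 cells (Rattus norvegicus) for inhibition, read by sulforhodamine B assay (a higher number here means a weaker inhibitor, a lower number a stronger inhibitor), compound 1 gives 25000 nM and compound 2 gives 13000 nM, so compound 1 stands within the usual scatter of the only other measured compound. Compound 3 `CC(C)COc1ccc(CC2SC(=O)NC2=O)cc1` keeps the core of compound 1 but carries isopropyl in place of cyclopentyl on a saturated chain carbon bound to an oxygen on an aromatic ring. Within the data shown here, no measured pair shows this change alone, so a shift no larger than the scatter, towards a slightly higher number, is expected: the estimated step is a 1.2-fold higher number from compound 1 to compound 3 (0.08 log units; within the scatter). For compound 3 the expected value is 30000 nM, within an estimated range of 12000 nM to 80000 nM.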

Compound 3, half-maximal inhibitory concentration: 25000 nM
The estimate for compound 3 lay 1.2-fold (0.08 log units) above the measured number; the measured number falls inside the stated range.
By their numbers in this assay, from the lowest: compounds 2, 1 and 3 (each within the scatter of the next).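

In this assay, within the data shown here, isopropyl in place of cyclopentyl on a saturated chain carbon bound to an oxygen on an aromatic ring gives no change at the digits printed from compound 1 to compound 3 (within the scatter), the first comparison here that differs in one place. At this position, then, the five-membered ring can give way to an open group with fewer heavy atoms without any visible shift in the number. Nothing on hand explains this result. As far as these compounds go, whether an amine, a carboxylic acid or a longer chain at this place would move the number stays open. Compound 2 differs from the other compounds in more than one place, so its steps cannot be read.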